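From compound 2 to compound 4: a shorter ester chain

A few compounds are considered here, and "the series" means these few. Any claim that something is new, unique, unknown or untested is made for them only; others in the source may bear on it.

Measured in a functional assay on HCT-116 cells (Homo sapiens) for antiproliferative activity, read by MTT assay, with a stated time of 72 h; a lower number here means a stronger inhibitor, a higher number a weaker inhibitor:
- compound 1 `C/C=C1/[C@H](O[C@@H]2O[C@H](CO)[C@@H](O)[C@H](O)[C@H]2O)OC=C(C(=O)OC)[C@H]1CC(=O)OCCCCCCCCCCCCCCC`: 12300 nM
- compound 2 `C/C=C1/[C@H](O[C@@H]2O[C@H](COC(C)=O)[C@@H](OC(C)=O)[C@H](OC(C)=O)[C@H]2OC(C)=O)OC=C(C(=O)OC)[C@H]1CC(=O)OCCCCCCCCCCCCCCC`: 21000 nM
- compound 3 `C/C=C1/[C@H](O[C@@H]2O[C@H](CO)[C@@H](O)[C@H](O)[C@H]2O)OC=C(C(=O)OC)[C@H]1CC(=O)OCCC1CCCCC1`: 13700 nM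

The three values lie close together, and compound 2 at 21000 nM sits within the usual scatter of both compound 1 and compound 3. Compound 4 `C/C=C1/[C@H](O[C@@H]2O[C@H](COC(C)=O)[C@@H](OC(C)=O)[C@H](OC(C)=O)[C@H]2OC(C)=O)OC=C(C(=O)OC)[C@H]1CC(=O)OCCC` has not yet been measured. It differs from compound 2 by hydrogen in place of dodecyl on a saturated chain carbon, three bonds along the chain from an oxygen next to a carbonyl group, which is hydrogen in place of dodecyl on a saturated chain carbon, three bonds along the chain from an oxygen next to a carbonyl group.

Among the compounds with values here, no measured pair isolates a change of this kind, so the expectation for this assay rests on little. Compound 3 at 13700 nM carries a different ester group yet stays within the scatter of compound 1. Only a modest step toward a higher number is therefore expected. The expected change is a 1.4-fold higher number from compound 2 to compound 4 (0.15 log units; within the scatter). For compound 4 the estimated value is 30000 nM, with an expected range of 13000 nM to 70000 nM.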

Compound 4, half-maximal inhibitory concentration: 25700 nM
Compound 4: the middle estimate sits 1.2-fold (0.07 log units) above what was measured; low and high end bracket the measured number.
By their numbers in this assay, from the lowest: compounds 1, 3, 2 and 4 (each within the scatter of the next, the first and the last beyond it).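

In this assay, within the data shown here, the exchange of dodecyl for hydrogen on a saturated chain carbon, three bonds along the chain from an oxygen next to a carbonyl group, gives a 1.2-fold higher number from compound 2 to compound 4 (0.09 log units; within the scatter) and provides the first measured step at this position. On the core of compound 2, the ester chain can therefore be shortened by the whole dodecyl group while the number stays within the scatter, so this assay does not separate the long chain from the short one in this pair. Nothing measured here offers a reason for this result.

As far as these compounds go, it remains open whether an amine or a carboxylic acid at the end of the ester chain would carry the number beyond the scatter. The compounds shown also leave open whether the same shortening gives a similar step on the core of compound 1, with its free hydroxyl groups.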